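A few compounds are considered here, and "the series" means these few. Any claim that something is new, unique, unknown or untested is made for them only; others in the source may bear on it.

Measured in a functional assay (aorta) for inhibition, with Rattus norvegicus as the target; a lower number here means that less compound is needed, a higher number that more compound is needed for the effect:
- compound 1 `O=C1C=CC(=O)c2ncccc21`: 519 nM
- compound 2 `O=C1C(Nc2ccc(F)cc2)=CC(=O)c2ncccc21`: 541 nM
- compound 3 `O=C1C(Nc2cc(F)cc(F)c2)=CC(=O)c2ncccc21`: 449 nM

Compound 2, at 541 nM, stands within the scatter of both other compounds, so the three measurements do not separate. The next compound to be measured, compound 4 `O=C1C(Nc2ccc(OC(F)(F)F)cc2)=CC(=O)c2ncccc21`, has trifluoromethoxy in place of fluoro on an aromatic carbon, para to a large group (trifluoromethoxy in place of fluoro on an aromatic carbon). Among the measured compounds shown here, no measured pair differs in one place only, so no direct precedent exists for this change. For the measured compounds named here, the only guide is the narrow spread of the values so far: the core of compound 1 alone gives 519 nM, and compound 3, with its two fluoro groups, gives 449 nM. On that basis, no change beyond the scatter is expected in this assay. The expected result is a 1.1-fold lower number from compound 2 to compound 4 (0.03 log units; within the scatter), although a single compound offers weak support for this and the range is kept wide. The estimated value for compound 4 is 500 nM, with an expected range of 220 nM to 1100 nM.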

Compound 4, half-maximal effective concentration: 603 nM
For compound 4 the middle estimate is 1.2-fold (0.08 log units) below the measured one; the range from low to high includes it.
By their numbers in this assay, from the lowest: compounds 3, 1, 2 and 4 (each within the scatter of the next).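

In this assay, the step of a 1.1-fold higher number from compound 2 to compound 4 (0.05 log units; within the scatter) gives the series its first comparison of compounds that differ in one place only, with trifluoromethoxy in place of fluoro on an aromatic carbon, para to a large group. Among the compounds shown here, at this position, the larger group with its hydrogen-bond acceptor produces no difference that the assay can separate from fluoro, which the earlier compounds, with no such pair among them, could not show. No measurement bears on why the two groups read alike.

As far as these compounds go, whether an amine, a carboxylic acid or a longer alkyl chain at this carbon would move the number beyond the scatter remains open. Also open, from the compounds shown here alone, is whether a methyl group on the shared core would do so.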